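Working notes: removing the fluoro group from compound 3

The source may report more compounds than this note shows. Statements on the series, on what has been measured and on what is new or still open speak of the compounds shown alone.

- compound 1 `CN(C)CCn1cccc1/C=N/NC(=O)Nc1ccc(Oc2ccnc3[nH]ccc23)c(F)c1` – "not determined" (no result reported)
- compound 2 `CCN(CC)CCn1cccc1/C=N/NC(=O)Nc1ccc(Oc2ccnc3[nH]ccc23)cc1` – "not determined" (no result reported)
- compound 3 `O=C(N/N=C/c1cccn1CCCN1CCCCC1)Nc1ccc(Oc2ccnc3[nH]ccc23)c(F)c1` – 4840 nM

All three entries come from a functional assay on MCF7 cells (Homo sapiens) for antiproliferative activity, read by MTT assay, with a stated time of 72 h; a higher number here means a weaker inhibitor, a lower number a stronger inhibitor. Among the compounds with values here, compound 3 holds the only number, while compound 1 and compound 2 have no result, so it has no rank yet.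

Compound 4 `O=C(N/N=C/c1cccn1CCCN1CCCCC1)Nc1ccc(Oc2ccnc3[nH]ccc23)cc1` follows from compound 3 by one change, hydrogen in place of fluoro on an aromatic carbon. Within the data shown here, no measured pair shows the size of this step. In this assay no step beyond the scatter is expected, and the expectation rests only on compound 3 at 4840 nM. The expected step is a 1.1-fold lower number from compound 3 to compound 4 (0.03 log units; within the scatter). Compound 4 is estimated at 4500 nM, with an expected range from 1700 nM to 12000 nM.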

Compound 4, half-maximal inhibitory concentration: 4690 nM
For compound 4 the middle estimate is 1.0-fold (0.02 log units) below the measured one; low and high end bracket the measured number.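

In this assay, the series now has its first measured step: hydrogen in place of fluoro on an aromatic carbon gives a 1.0-fold lower number from compound 3 to compound 4 (0.01 log units; within the scatter). At this position, ortho to a large group and meta to a large group, the two substituents therefore cannot be told apart in this read-out, at least with the rest of compound 3 unchanged. Nothing available accounts for this result.

Going by these compounds, whether chloro or methoxy at this position would shift the number remains open. So does whether the fluoro-to-hydrogen exchange would stay as small with morpholine in place of the piperidine.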